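Butoxy purinedione amides: a hydroxylated anilide step

A few compounds are considered here, and "the series" means these few. Any claim that something is new, unique, unknown or untested is made for them only; others in the source may bear on it.

Measured so far:
compound 1, `CCCOc1nc2c(c(=O)n(C)c(=O)n2C)n1CCCC(=O)Nc1cc(C(C)(C)C)ccc1O`: 41200 nM
compound 2, `CCCCOc1nc2c(c(=O)n(C)c(=O)n2C)n1CCCC(=O)Nc1ccc(C(C)CC)cc1`: 20000 nM

Of the compounds shown here, two have been measured in an assay on isolated protein for inhibition of high affinity 3',5'-cyclic-AMP phosphodiesterase 7A (Homo sapiens), read by cAMP accumulation, with a stated time of 10 min; on this read-out lower numbers stand for stronger inhibition and higher numbers for weaker inhibition. Compound 1 gives 41200 nM there, and compound 2 gives 20000 nM. Compound 2 thus holds the lower of the two numbers; compound 1 lies a little more than two steps of the usual scatter away, so the gap between them is real, if modest.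

Compound 3, `CCCCOc1nc2c(c(=O)n(C)c(=O)n2C)n1CCCC(=O)Nc1cc(C(C)(C)C)ccc1O`, is not yet measured. It differs from compound 2 in one place: 2-hydroxy-5-(tert-butyl)phenyl in place of 4-(sec-butyl)phenyl on an amide-type nitrogen. The shared core and its butoxy chain stay untouched. The group that enters is the same anilide that compound 1 carries, and compound 1, with a shorter alkoxy chain, gives 41200 nM. On that basis, the step is expected to go toward weaker inhibition, roughly the size of the gap seen between compound 2 and compound 1, and probably beyond the scatter: from compound 2 to compound 3 the change is expected to be a 1.8-fold higher number from compound 2 to compound 3 (0.24 log units; within the scatter). For compound 3 itself, the estimate in this assay is 35000 nM, within a range from 12000 nM to 100000 nM.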

Compound 3, half-maximal inhibitory concentration: 5070 nM
Compound 3: the middle estimate sits 6.9-fold (0.84 log units) above what was measured, and the stated range ends above it.
By their numbers in this assay, from the lowest: compound 3; then compound 2; then compound 1.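

In this assay, putting 2-hydroxy-5-(tert-butyl)phenyl in place of 4-(sec-butyl)phenyl on the amide-type nitrogen, with the butoxy chain held fixed, gives a 3.9-fold lower number from compound 2 to compound 3 (0.60 log units; beyond the scatter), so the group at this position clearly shapes the result, and here the hydroxylated group gives the lower number. Going by these compounds alone, the alkoxy chain matters as well: with that same hydroxylated anilide held fixed, extending propoxy to butoxy, which is methyl in place of hydrogen on a saturated chain carbon, gives an 8.1-fold lower number from compound 1 to compound 3 (0.91 log units; beyond the scatter), a step that only this new compound makes readable. No measurement is available that explains either change.

The swap at the amide-type nitrogen alters several things at once, adding the hydroxyl group and replacing sec-butyl with tert-butyl at a different place on the ring, so these compounds cannot show which of these alterations accounts for the lower number. They also leave open what a methoxy group or an amine in place of the hydroxyl group would do, and whether a pentyloxy chain would continue the trend seen on going from propoxy to butoxy.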